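From compound 1 to compound 4: an expected shift

The source may report more compounds than this note shows. Statements on the series, on what has been measured and on what is new or still open speak of the compounds shown alone.

Compound 1 `CCS(=O)(=O)Nc1cc(-c2ccc3ncnc(Nc4ccc(OC)c(OC)c4)c3c2)cnc1OC`: 2590 nM
Compound 2 `CCS(=O)(=O)Nc1cc(-c2ccc3ncnc(Nc4ccc(OCc5ccc(F)cc5)c(Cl)c4)c3c2)cnc1OC`: 14600 nM
Compound 3 `CCCCS(=O)(=O)Nc1cc(-c2ccc3ncnc(Nc4cccc(C(=O)OCC)c4)c3c2)cnc1OC`: 37200 nM

Of the compounds shown here, three on a shared core have been tested in a functional assay on BT-549 cells (Homo sapiens) for cytotoxicity, read by sulforhodamine B assay, with a stated time of 72 h; a lower number here means a stronger inhibitor, a higher number a weaker inhibitor. Compound 1 stands lowest of the three with 2590 nM; compound 2 at 14600 nM and compound 3 at 37200 nM both lie beyond the scatter from it, though each also differs from compound 1 in more than one place.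

Compound 4 `CCS(=O)(=O)Nc1cc(-c2ccc3ncnc(Nc4ccc(F)nc4)c3c2)cnc1OC` differs from compound 1 in one place only: 6-fluoropyridin-3-yl in place of 3,4-dimethoxyphenyl on a nitrogen on an aromatic ring. Going by the values given here, no measured pair isolates this change, so the outlook rests on the spread already seen, where compounds 2 and 3 gave higher numbers. A moderately higher number is expected for compound 4, a step of a 2.3-fold higher number from compound 1 to compound 4 (0.36 log units; beyond the scatter) that probably goes beyond the scatter. Compound 4 is estimated at 6000 nM, within 1500 nM to 25000 nM.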

Compound 4, half-maximal inhibitory concentration: 4780 nM
Estimate against measurement, compound 4: 1.3-fold (0.10 log units) above, within the range that was stated.
By their numbers in this assay, from the lowest: compounds 1 and 4 (each within the scatter of the next); then compound 2; then compound 3.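

In this assay, placing 6-fluoropyridin-3-yl on this nitrogen instead of 3,4-dimethoxyphenyl gives a 1.8-fold higher number from compound 1 to compound 4 (0.27 log units; within the scatter) and so no real change in the read-out. This single-place comparison shows that the two methoxy groups can be absent and a ring nitrogen and fluorine present with no change beyond the scatter. Nothing measured here bears on the reason for this result. Going by these compounds, what remains open is how a ring carrying an amine or a carboxylic acid would behave at this position.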